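Adding an isopropyl group to a shorter-linker coumarin propargylamine

The source may hold more compounds than are shown below. What is called first, only, known or untested is meant among the compounds shown, and "the series" means these compounds.

Compound 2 `C#CCN(CCCCOc1ccc2ccc(=O)oc2c1)Cc1ccccc1` and compound 1 `C#CCN(CCCCOc1ccc2ccc(=O)oc2c1)Cc1ccc(C(C)C)cc1` share a core and differ in one place, (isopropyl in place of hydrogen on an aromatic carbon). In an assay on isolated protein for inhibition of Amine oxidase [flavin-containing] B (Homo sapiens), read by fluorescence and Amplex Red, with stated times of 15 min and 20 min (on this read-out higher numbers stand for weaker inhibition and lower numbers for stronger inhibition), compound 2 gives 978 nM, while compound 1 gives 3500 nM, so the step of a 3.6-fold higher number from compound 2 to compound 1 (0.55 log units; beyond the scatter) weakened inhibition. Compound 3 `C#CCN(CCCOc1ccc2ccc(=O)oc2c1)Cc1ccccc1` has a different core; how its core differs from that of compound 2 is not broken down here. In this assay compound 3 gives 3740 nM. Compound 4 `C#CCN(CCCOc1ccc2ccc(=O)oc2c1)Cc1ccc(C(C)C)cc1` carries the same change on the core of compound 3, (isopropyl in place of hydrogen on an aromatic carbon). Because the step of a 3.6-fold higher number from compound 2 to compound 1 (0.55 log units; beyond the scatter) made inhibition weaker on a closely related core, a step of similar size, a 3.2-fold higher number from compound 3 to compound 4 (0.51 log units; beyond the scatter), is expected here, though it rests on one example only. Compound 4 is therefore estimated at 12000 nM.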

Compound 4, half-maximal inhibitory concentration: 7580 nM
Compound 4: middle estimate off by 1.6-fold (0.20 log units), on the high side; the measured number falls inside the stated range.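

In this assay, isopropyl in place of hydrogen on the aromatic carbon again weakened inhibition, with a 2.0-fold higher number from compound 3 to compound 4 (0.31 log units; beyond the scatter). The change moved the number in the same direction on both cores, and the sizes of the two steps cannot be told apart: the same change on two cores in this assay, a 3.6-fold higher number (0.55 log units; beyond the scatter) from compound 2 to compound 1 and a 2.0-fold higher number (0.31 log units; beyond the scatter) from compound 3 to compound 4, 1.8-fold (0.25 log units) apart, within the scatter of two such steps This shows that the change carried over between these two cores, but two pairs make no general rule, and they do not show why inhibition weakens.

The compounds shown leave open whether a smaller group, such as methyl, or a halogen, such as chlorine, on that same aromatic carbon would weaken inhibition as well. They also leave open whether the change would carry over to a core with a longer chain.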